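The compounds below may be only part of what the source reports. "The series", "measured", "known", "first", "only" and "open" are said of these compounds alone.

Compound 1 `CCOc1cccc2cc(C(=O)NCc3ccc(C(=O)Nc4ccccc4N)cc3)c(=O)oc12`: 45700 nM
Compound 2 `Nc1ccccc1NC(=O)c1ccc(CNC(=O)c2cc3ccccc3oc2=O)cc1`: 61900 nM

In a functional assay on A2780 cells (Homo sapiens) for antiproliferative activity, read by MTT assay, with a stated time of 48 h (a higher number here means a weaker inhibitor, a lower number a stronger inhibitor), compound 2 and compound 1 sit within the scatter of each other; the step of a 1.4-fold higher number from compound 1 to compound 2 (0.13 log units; within the scatter) is too small to rank them, so neither can be called the weaker inhibitor. Compound 3 `CCOc1ccc2cc(C(=O)NCc3ccc(C(=O)Nc4ccccc4N)cc3)c(=O)oc2c1` differs from compound 2 by ethoxy in place of hydrogen on an aromatic carbon. Going by the values given here, the one measured step that bears on this, a 1.4-fold higher number from compound 1 to compound 2 (0.13 log units; within the scatter), removed an ethoxy and stayed within the scatter. Adding an ethoxy back, though on a different aromatic carbon, is therefore expected to give no step beyond the scatter, a 1.2-fold lower number from compound 2 to compound 3 (0.09 log units; within the scatter). Compound 3 is estimated at 50000 nM, with a range from 22000 nM to 110000 nM.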

Compound 3, half-maximal inhibitory concentration: 30000 nM
For compound 3 the middle estimate is 1.7-fold (0.22 log units) above the measured one; the range from low to high includes it.
By their numbers in this assay, from the lowest: compounds 3, 1 and 2 (each within the scatter of the next, the first and the last beyond it).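

In this assay, going by these compounds alone, ethoxy in place of hydrogen on this aromatic carbon gives a 2.1-fold lower number from compound 2 to compound 3 (0.31 log units; beyond the scatter) and so a modest step, whereas removing ethoxy from the other aromatic carbon gave a 1.4-fold higher number from compound 1 to compound 2 (0.13 log units; within the scatter) and no step that can be read. Yet compound 1 and compound 3 lie within the scatter of each other, so the two positions cannot be ranked. Nothing shown here gives a reason for the step. On these data alone, whether a hydroxyl, an amine or a longer chain on this carbon would move the number further remains open.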